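Replacing a chain oxygen with carbon in an endoperoxide series

The source may report more compounds than this note shows. Statements on the series, on what has been measured and on what is new or still open speak of the compounds shown alone.

Of the compounds shown here, three sharing one core have been measured in an ADME assay on microsomes from liver (Homo sapiens) for metabolic stability, read by LC-MS, tested at 1 uM; a lower number here means slower removal, a higher number faster removal of the compound. Compound 1 `O=S(=O)(c1ccc([C@H]2CC[C@]3(CC2)OOC2(O3)C3CC4CC(C3)CC2C4)cc1)N1CCNCC1` gives 16 mL.min-1.g-1. Compound 2 `NCCOCCOc1ccc([C@H]2CC[C@]3(CC2)OOC2(O3)C3CC4CC(C3)CC2C4)cc1` gives < 7 mL.min-1.g-1, which is a limit of the assay rather than a number. Compound 3 `CS(=O)(=O)N1CCN(CCCOc2ccc([C@H]3CC[C@]4(CC3)OOC3(O4)C4CC5CC(C4)CC3C5)cc2)CC1` gives 68 mL.min-1.g-1. Compound 2 thus stands at the slow end of what is shown, at the limit of < 7 mL.min-1.g-1 in this assay, at which 1 of the 3 values shown sits. The step of an at least 2.2-fold lower number from compound 1 to compound 2 (0.35 log units; beyond the scatter) moves into that limit, and the step of an at least 9.7-fold higher number from compound 2 to compound 3 (0.98 log units; beyond the scatter) moves away from it.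

Compound 4 `NCCCCOc1ccc([C@H]2CC[C@]3(CC2)OOC2(O3)C3CC4CC(C3)CC2C4)cc1` has not yet been measured. It differs from compound 2 only in that (2-aminoethyl in place of 2-aminoethoxy on a saturated chain carbon, two bonds along the chain from an oxygen on an aromatic ring); seen from the aromatic oxygen, 2-(2-aminoethoxy)ethoxy becomes 4-aminobutoxy. Neither measured step matches this exchange of one chain atom: both steps change the whole end group. Since compound 2 sits at a limit, any step from it can only be read upward or as unchanged. A small step is expected, an at least 1.1-fold higher number from compound 2 to compound 4 (0.05 log units; that floor lies within the scatter), in this assay. Compound 4 is therefore estimated at 8 mL.min-1.g-1, within a range of 4 mL.min-1.g-1 to 20 mL.min-1.g-1.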

Compound 4, intrinsic clearance in microsomes: < 7 mL.min-1.g-1
Compound 4: a limit, no number (the forecaster's own chance of this, stated with the estimate: 45%); middle value at least 1.1-fold (0.05 log units) from the limit.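

Exchanging the chain oxygen for carbon, so that 2-(2-aminoethoxy)ethoxy becomes 4-aminobutoxy, leaves compound 4 at the same assay limit as compound 2 in this assay: the limit of < 7 mL.min-1.g-1 in this assay, at which 2 of the 4 values shown sit. The step between these two compounds cannot be read, as both values are limits, but the chain oxygen is clearly not required for a value at this limit. Against the other two compounds, the new value gives an at least 9.7-fold lower number from compound 3 to compound 4 (0.98 log units; beyond the scatter) and an at least 2.2-fold lower number from compound 1 to compound 4 (0.35 log units; beyond the scatter).

Whether the exchange changes the rate of removal at all stays hidden beneath the limit. Going by these compounds, it also remains open how a longer chain, or a carboxylic acid in place of the amine, would behave in this assay.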